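Swapping cyclopentyl for 4-propylphenyl on the shared core

A few compounds are considered here, and "the series" means these few. Any claim that something is new, unique, unknown or untested is made for them only; others in the source may bear on it.

Compound 2, `O=C1C=C(NC2CCCC2)C(=O)c2c1nc1n2[C@H]2OC[C@@H](O)[C@H]2OC1`, carries a cyclopentyl group on an amine nitrogen of the shared core. In a functional assay on ECa-109 cells for inhibition, with ECa-109 cell line (Homo sapiens) as the target, read by sulforhodamine B assay (on this read-out higher numbers stand for weaker inhibition and lower numbers for stronger inhibition), compound 2 gives > 16000 nM, which is a limit of the assay rather than a measured number. Its neighbour compound 1, `Cc1ccc(NC2=CC(=O)c3nc4n(c3C2=O)[C@H]2OC[C@@H](O)[C@H]2OC4)cc1`, bears 4-methylphenyl at the same position and in this assay compound 1 gives 3480 nM. For the measured compounds named here, the one step that connects the two, an at least 4.5-fold higher number from compound 1 to compound 2 (0.66 log units; beyond the scatter), shows that replacing the aryl group by the saturated ring weakened inhibition, an effect tied to the limit of > 16000 nM in this assay, at which 1 of the 2 values shown sits.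

Compound 3, `CCCc1ccc(NC2=CC(=O)c3nc4n(c3C2=O)[C@H]2OC[C@@H](O)[C@H]2OC4)cc1`, has not yet been measured. It differs from compound 2 by 4-propylphenyl in place of cyclopentyl on an amine nitrogen. Going by the values given here, this change reverses the direction of the only measured step, reinstating an aryl group on the amine nitrogen, so the expectation is a return toward the level of compound 1. Among the compounds with values here, the propyl chain is longer than the methyl of compound 1, but no measured step speaks to that detail. Compound 3 is therefore expected to give 3500 nM in this assay, within 1200 nM to 12000 nM, meaning an expected step of an at least 4.5-fold lower number from compound 2 to compound 3 (0.66 log units; beyond the scatter).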

Compound 3, half-maximal inhibitory concentration: > 4000 nM
Compound 3: a limit, no number (the forecaster's own chance of this, stated with the estimate: 15%); middle value at least 1.1-fold (0.05 log units) from the limit.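

In this assay compound 3 gives > 4000 nM, which is a limit of the assay and not a number, so putting an aryl group back on the amine nitrogen does not by itself bring a measured value at this position. For the compounds shown here, the one comparison that can be read is an at least 1.1-fold higher number from compound 1 to compound 3 (0.06 log units; that floor lies within the scatter), and with that floor inside the scatter, ethyl in place of hydrogen on the saturated chain carbon bound to an aromatic carbon can be called neither harmful nor harmless. Both ends of the step joining compound 2 and compound 3 are limits, so that step cannot be read, and cyclopentyl and 4-propylphenyl cannot be ranked against each other here.

Where compound 3 truly lies relative to compound 1 stays open, and with it whether the length of the chain on the aromatic ring matters at all in this series. Unsubstituted phenyl, 4-ethylphenyl or a phenyl ring bearing a carboxylic acid on the same amine nitrogen would be the groups to place between these readings.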